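The source may hold more compounds than are shown below. What is called first, only, known or untested is meant among the compounds shown, and "the series" means these compounds.

In a functional assay on ECa-109 cells (Homo sapiens) for inhibition, read by MTT assay, with a stated time of 72 h (a lower number here means a stronger inhibitor, a higher number a weaker inhibitor), compound 1 `COc1ccccc1Nc1nc(SCc2cn(CC(=O)NC(=O)Nc3ccccn3)nn2)nc(-c2ccc(C)cc2)c1C#N` gives 7850 nM. Compound 2 `Cc1ccc(Nc2nc(SCc3cn(CC(=O)NC(=O)Nc4ccccn4)nn3)nc(-c3ccc(C)cc3)c2C#N)cc1` carries a 4-methylphenyl in place of the 2-methoxyphenyl on a nitrogen on an aromatic ring, and in this assay compound 2 is reported only as a limit of the assay, > 64000 nM. The step of an at least 8.1-fold higher number from compound 1 to compound 2 (0.91 log units; beyond the scatter) is therefore bounded on one side by the limit of > 64000 nM in this assay, at which 1 of the 2 values shown sits. Compound 3 `Cc1ccc(Nc2nc(SCc3cn(CC(=O)NC(=O)Nc4ccccn4)nn3)nc(-c3ccccc3)c2C#N)cc1` differs from compound 2 by hydrogen in place of methyl on an aromatic carbon of a six-membered aromatic ring of carbon only. Within the data shown here, the single measured step concerns the group on the nitrogen and not this methyl, so no measured step bears directly on the change from compound 2 to compound 3, and compound 2 itself sits at the limit. The expected step is therefore none beyond the scatter, a step that the limit leaves unreadable from compound 2 to compound 3. For compound 3 the estimate in this assay is 80000 nM, within a range from 30000 nM to 250000 nM, and the value is expected most likely to come back again only as a limit.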

Compound 3, half-maximal inhibitory concentration: 24600 nM
For compound 3 the middle estimate is 3.3-fold (0.51 log units) above the measured one; measured number outside the range, below it.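

Until now only the group on the nitrogen had varied; compound 3 changes the other aryl group, 4-methylphenyl to phenyl, and in this assay this gives an at least 2.6-fold lower number from compound 2 to compound 3 (0.41 log units; beyond the scatter). So this position, too, bears on the read-out, and compound 3 shows that the 4-methylphenyl on the nitrogen does not by itself put a compound at the limit. The full size of the step cannot be read, as compound 2 is known only through a limit: the limit of > 64000 nM in this assay, at which 1 of the 3 values shown sits.

As far as these compounds go, compound 1 and compound 3 differ in two places, so whether the loss of this methyl would count the same with the 2-methoxyphenyl on the nitrogen stays open. Also open, from the compounds shown here alone, is what a chlorine, a methoxy group or a longer chain such as ethyl would do in the place of this methyl.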